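The compounds below may be only part of what the source reports. "The series", "measured", "known", "first", "only" and "open" are said of these compounds alone.

Measured so far in a functional assay on HEK293 cells for inhibition of 5-hydroxytryptamine receptor 6 (Homo sapiens), read by cAMP accumulation; a lower number here means a stronger inhibitor, a higher number a weaker inhibitor:
compound 1 `CNc1nn2c(C)cc(C)nc2c1S(=O)(=O)c1ccccc1`, which gives 0.263 nM; 0.26 nM (2 entries)
compound 2 `CNc1nn2c(N)cc(C)nc2c1S(=O)(=O)c1ccccc1`, which gives 0.302 nM
compound 3 `CNc1nn2c(N)cc(C)nc2c1S(=O)(=O)c1cccc(Cl)c1`, which gives 0.219 nM

Among the two compounds with a single number, compound 2 stands at the top, but its nearest neighbour is compound 3 and the step of a 1.4-fold lower number from compound 2 to compound 3 (0.14 log units; within the scatter) lies within the scatter, so the two are not truly separated. Among the measured compounds shown here, compound 1 has been run twice, (the several entries of compound 1 in this assay, 0.263 nM; 0.26 nM (2 entries)), and both entries sit close to the number of compound 2; no step between those two is worked out here, so only their values stand side by side.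

The unmeasured compound 4 `CNc1nn2c(NC)cc(C)nc2c1S(=O)(=O)c1ccccc1` differs from compound 2 by methyl in place of hydrogen on a nitrogen on an aromatic ring. For the measured compounds named here, the one measured step, a 1.4-fold lower number from compound 2 to compound 3 (0.14 log units; within the scatter), concerns a different part of the molecule and stayed within the scatter, and compound 1 with its methyl group and compound 2 with its amino group give numbers that hardly differ. For the step from compound 2 to compound 4 no change beyond the scatter is therefore expected: a 1.0-fold lower number from compound 2 to compound 4 (0.00 log units; within the scatter). Compound 4 is estimated at 0.3 nM, with a range from 0.12 nM to 0.75 nM.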

Compound 4, inhibition constant: 0.575 nM
Compound 4: the middle estimate sits 1.9-fold (0.28 log units) below what was measured, and the stated range covers the measured number.
By their numbers in this assay, from the lowest: compounds 3, 2 and 4 (each within the scatter of the next, the first and the last beyond it).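

This is the first change shown on the amino group of compound 2; the earlier step, which added chloro, concerned a different part of the molecule. In this assay, methyl in place of hydrogen on this nitrogen gives a 1.9-fold higher number from compound 2 to compound 4 (0.28 log units; within the scatter), so at this place the change from amino to methylamino cannot be told apart from no change at all. Compound 4 rests on a single entry, and how closely repeat entries can agree is seen in compound 1: the several entries of compound 1 in this assay, 0.263 nM; 0.26 nM (2 entries)

The compounds shown leave open whether a larger group on this nitrogen, such as ethyl or a longer chain, would move the number beyond the scatter. They also leave open what a second methyl on the same nitrogen, giving dimethylamino, or an acetyl group there would do.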